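Series notes: step from compound 3 to compound 4

This account rests on a few compounds, and the source may have more. Where it says the series, first, only, none or still open, it means among the compounds named here.

Compound 1 `CC(C)n1nc(-c2cc(C3CCCCC3)on2)c2c(N)ncnc21` gives 9500 nM in an assay on BaF3 cells for inhibition of proto-oncogene tyrosine-protein kinase receptor Ret (Homo sapiens), read by MTT assay, with a stated time of 48 h; on this read-out higher numbers stand for weaker inhibition of growth and lower numbers for stronger inhibition of growth.
Compound 2 `CC(C)n1nc(-c2ccon2)c2c(N)ncnc21` gives 3210 nM in this assay.
Compound 3 `Nc1ncnc2c1c(-c1cc(C3CC3)on1)nn2C1CCCCC1` gives 520 nM in this assay.

Compound 3 gives the lowest number of the three, with compound 2 and compound 1 both beyond the scatter above it. Compound 4 `CC(C)(O)Cn1nc(-c2cc(C3CC3)on2)c2c(N)ncnc21` differs from compound 3 in one place: 2-hydroxy-2-methylpropyl in place of cyclohexyl on an aromatic nitrogen. For the measured compounds named here, the only measured single-point step, a 3.0-fold lower number from compound 1 to compound 2 (0.47 log units; beyond the scatter), removes a cyclohexyl at a different place, on an aromatic carbon, so no measured step bears directly on this change. Going by the values given here, compound 2 and compound 3 differ in two places, and their values show only that compound 3 sits below compound 2. Among the compounds with values here, with no direct precedent, a modest loss is allowed for, and the expected step for compound 4 is a 1.7-fold higher number from compound 3 to compound 4 (0.24 log units; within the scatter). Compound 4 is estimated at 900 nM, with a range from 200 nM to 3500 nM.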

Compound 4, concentration for 50% growth inhibition: 1770 nM
Beside the measured number, compound 4's estimate is 2.0-fold (0.29 log units) below it; the range from low to high includes it.
By their numbers in this assay, from the lowest: compound 3; then compounds 4 and 2 (each within the scatter of the next); then compound 1.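

Putting 2-hydroxy-2-methylpropyl in place of cyclohexyl on the aromatic nitrogen gives a 3.4-fold higher number from compound 3 to compound 4 (0.53 log units; beyond the scatter) in this assay. For the compounds shown here, this is the only single-place step read at this nitrogen, and it shows that the position responds beyond the scatter with the 5-cyclopropyl-1,2-oxazol-3-yl group held constant. Nothing available accounts for the size or direction of this step.

Still open, on these data alone, is whether the step follows the loss of the ring or the entry of the hydroxyl. A plain 2-methylpropyl chain on this nitrogen would separate the two, and an amine in place of the hydroxyl would test that end of the chain.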